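The source may hold more compounds than are shown below. What is called first, only, known or untested is meant among the compounds shown, and "the series" means these compounds.

Of the compounds shown here, three that share one core have been measured in a functional assay on Jurkat cells for inhibition of nuclear factor NF-kappa-B complex (Homo sapiens); on this read-out lower numbers stand for stronger inhibition and higher numbers for weaker inhibition. Compound 1 `CCOC(=O)c1cnc(C)nc1NN1C(=O)C=C(C)C1=O` carries a methyl on the aromatic carbon between two ring nitrogen atoms and gives 16000 nM. Compound 2 `CCOC(=O)c1cnc(-c2csc(C)n2)nc1NN1C(=O)C=C(C)C1=O` carries a 2-methyl-1,3-thiazol-4-yl at that place and gives 8000 nM, a change that is a 2.0-fold lower number from compound 1 to compound 2 (0.30 log units; within the scatter). Compound 3 `CCOC(=O)c1cnc(-c2cccc(Br)c2)nc1NN1C(=O)C=C(C)C1=O` carries a 3-bromophenyl at the same place and gives 700 nM, the lowest of the three numbers; the gaps to it are a 23-fold lower number from compound 1 to compound 3 (1.36 log units; beyond the scatter) and an 11-fold lower number from compound 2 to compound 3 (1.06 log units; beyond the scatter). Compound 4 `CCOC(=O)c1cnc(-c2ccc(C)s2)nc1NN1C(=O)C=C(C)C1=O` has not yet been measured. Its difference from compound 3 is 5-methylthiophen-2-yl in place of 3-bromophenyl on an aromatic carbon. The measured step that bears most on this is the one from a five-membered aromatic ring with one hetero atom to the 3-bromophenyl, which was an 11-fold lower number from compound 2 to compound 3 (1.06 log units; beyond the scatter). Going by the values given here, the group entering compound 4 is again a five-membered aromatic ring with one hetero atom and a methyl, so compound 4 is expected to sit nearer compound 2 than compound 3, although the ring of compound 2 and that of compound 4 are not the same and no measured step separates them. Compound 4 is therefore expected to show a 4.3-fold higher number from compound 3 to compound 4 (0.63 log units; beyond the scatter) in this assay. The estimate for compound 4 is 3000 nM, with a range from 1000 nM to 10000 nM.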

Compound 4, half-maximal inhibitory concentration: 200 nM
Beside the measured number, compound 4's estimate is 15-fold (1.18 log units) above it, and the stated range ends above it.
By their numbers in this assay, from the lowest: compound 4; then compound 3; then compounds 2 and 1 (each within the scatter of the next).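

In this assay, this result shows that the place between two ring nitrogen atoms does not need a six-membered aromatic ring of carbon only or a bromine to give a low number, since 5-methylthiophen-2-yl brings a 3.5-fold lower number from compound 3 to compound 4 (0.54 log units; beyond the scatter) and is the lowest of the four. It also shows that a five-membered aromatic ring does not by itself fix the outcome: replacing the 2-methyl-1,3-thiazol-4-yl with this group gives a 40-fold lower number from compound 2 to compound 4 (1.60 log units; beyond the scatter) even though both groups carry a methyl, and the widest gap at this place is now an 80-fold lower number from compound 1 to compound 4 (1.90 log units; beyond the scatter) in favour of the 5-methylthiophen-2-yl. No measurement here explains why these groups differ so much.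

The compounds shown do not separate the contribution of the thiophene ring from that of its methyl, which a plain thiophen-2-yl or a 5-chlorothiophen-2-yl at the same place would address. They also leave open how a furan-2-yl, a 3-methylphenyl or a simple amine would compare there.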